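Replacing a fluorinated pyridine by a methylphenyl group

The source may report more compounds than this note shows. Statements on the series, on what has been measured and on what is new or still open speak of the compounds shown alone.

Compound 3 `Cc1cc(NC(=O)Cn2nnc(-c3cccc(F)n3)n2)n(C2CCCCC2)n1` was tested in an assay on HEK293 cells for activation of Kir3.1/Kir3.2 (Homo sapiens), read by thallium flux; on this read-out higher numbers stand for larger maximal responses and lower numbers for smaller maximal responses. For compound 3 the result is a limit of the assay rather than a number, > 83%. Two close relatives give full numbers: compound 1 `Cc1cc(NC(=O)Cn2nnc(-c3cccnc3)n2)n(C2CCCCC2)n1` reaches 96% in this assay, and compound 2 `Cc1cc(NC(=O)Cn2nnc(-c3ccc(F)c(F)c3)n2)n(C2CCCCC2)n1` reaches 93%. Compound 4 `Cc1ccc(-c2nnn(CC(=O)Nc3cc(C)nn3C3CCCCC3)n2)cc1` has not yet been measured; it differs from compound 3 in a single place: 4-methylphenyl in place of 6-fluoropyridin-2-yl on an aromatic carbon. The nearest measured guide is the exchange of pyridin-3-yl for 3,4-difluorophenyl, which gave a number 3 percentage points lower from compound 1 to compound 2 (within the scatter). The two steps that end at compound 3, a step that the limit leaves unreadable from compound 1 to compound 3 and a step that the limit leaves unreadable from compound 2 to compound 3, cannot be sized because of the limit of > 83% in this assay, at which 1 of the 3 values shown sits. Among the measured compounds shown here, with only one readable step, and that one flat, compound 4 is expected to show no change beyond the scatter, a step that the limit leaves unreadable from compound 3 to compound 4. The maximal response of compound 4 is therefore estimated at 90%, within a range from 75% to 102%.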

Compound 4, largest response reached (Emax), in percent of the reference or control that the assay uses: 86%
Estimate against measurement, compound 4: 4 percentage points above; low and high end bracket the measured number.
By their numbers in this assay, from the lowest: compounds 4, 2 and 1 (each within the scatter of the next).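

In this assay, a 4-methylphenyl group on this aromatic carbon of the five-membered ring, a ring of carbon only with no fluorine, shows no change beyond the scatter from the earlier groups: replacing 3,4-difluorophenyl gives a number 7 percentage points lower from compound 2 to compound 4 (within the scatter), and replacing pyridin-3-yl gives a number 10 percentage points lower from compound 1 to compound 4 (within the scatter). Among these three compounds, neither a ring nitrogen nor fluorine is needed at this position for a large maximal response. The steps that involve compound 3 cannot be read: the limit of > 83% in this assay, at which 1 of the 4 values shown sits.

The compounds shown all carry a six-membered aromatic ring here, so it remains open whether the response holds with a saturated amine such as morpholine or with a phenyl ring bearing a carboxylic acid. Maximal response alone also leaves open how the concentration needed for activation changes across these groups.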